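Cyclopropylcarbamoyl in place of cyclopropylsulfonyl: an expected step

The source may hold more compounds than are shown below. What is called first, only, known or untested is meant among the compounds shown, and "the series" means these compounds.

Three compounds were measured in a functional assay on LNCaP cells (Homo sapiens) for antiproliferative activity, read by MTT assay, with a stated time of 3 days (on this read-out higher numbers stand for weaker inhibition and lower numbers for stronger inhibition), and gave these values:
compound 1 `COc1cc(O)c2c(=O)cc(-c3ccc(NS(C)(=O)=O)cc3)oc2c1OC(C)C`: 15400 nM
compound 2 `CCCS(=O)(=O)Nc1ccc(-c2cc(=O)c3c(O)cc(OC)c(OC(C)C)c3o2)cc1`: 30500 nM
compound 3 `COc1cc(O)c2c(=O)cc(-c3ccc(NS(=O)(=O)C4CC4)cc3)oc2c1OC(C)C`: 8800 nM

Compound 3 sits level with compound 1 within the usual scatter, as a 1.8-fold lower number from compound 1 to compound 3 (0.24 log units; within the scatter) shows. It stands clearly under compound 2, with a 3.5-fold lower number from compound 2 to compound 3 (0.54 log units; beyond the scatter) as the measured step. The next compound, compound 4 `COc1cc(O)c2c(=O)cc(-c3ccc(NC(=O)NC4CC4)cc3)oc2c1OC(C)C`, has not yet been measured. It carries cyclopropylcarbamoyl in place of cyclopropylsulfonyl on a nitrogen on an aromatic ring, and the count of that difference is cyclopropylcarbamoyl in place of cyclopropylsulfonyl on a nitrogen on an aromatic ring for the reader to weigh.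

The measured steps bear on this only indirectly. All of them alter the group on the sulfonyl sulfur, and none replaces the sulfonyl itself. They are a 2.0-fold higher number from compound 1 to compound 2 (0.30 log units; within the scatter) together with the two above, so the largest is modest. The data therefore give no direction for the new change, and only a small step can be expected, with wide uncertainty. The expected step is a 1.1-fold higher number from compound 3 to compound 4 (0.06 log units; within the scatter) and nothing beyond the scatter is predicted. For compound 4 the estimated value is 10000 nM in this assay, with an expected range from 3000 nM to 35000 nM as its limits.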

Compound 4, half-maximal inhibitory concentration: 13800 nM
Compound 4: the middle estimate sits 1.4-fold (0.14 log units) below what was measured; low and high end bracket the measured number.
By their numbers in this assay, from the lowest: compounds 3, 4, 1 and 2 (each within the scatter of the next, the first and the last beyond it).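

In this assay, among these compounds, this is the first step that replaces the sulfonyl itself rather than the group on it, and on a nitrogen on an aromatic ring cyclopropylcarbamoyl stands in for cyclopropylsulfonyl with a 1.6-fold higher number from compound 3 to compound 4 (0.20 log units; within the scatter) as the result, even though the entering group has a hydrogen-bond donor and the leaving group has none. The same compound also reads level with the methylsulfonyl compound, with a 1.1-fold lower number from compound 1 to compound 4 (0.05 log units; within the scatter) as the step, and it stands clear of the propylsulfonyl compound, with a 2.2-fold lower number from compound 2 to compound 4 (0.34 log units; beyond the scatter) as a modest step, so among these four compounds a sulfonyl is not needed to reach this level of inhibition. No measurement shown here accounts for how the two linking groups come to read alike.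

On these data alone, it remains open whether the carbamoyl series would follow the sulfonyl series when the cyclopropyl is exchanged, as a methylcarbamoyl or propylcarbamoyl group would show. As far as these compounds go, it is also open how the antiproliferative read-out would respond to an acetyl group or a plain amine on the same nitrogen, on the shared core.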